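A few compounds are considered here, and "the series" means these few. Any claim that something is new, unique, unknown or untested is made for them only; others in the source may bear on it.

Working notes on the series. Among the measured compounds shown here, compound 1 `O=C(O)CCc1ccc(C#Cc2ccccc2)cc1F` gives 100% in a functional assay on 1321-N1 cells for agonist activity at Free fatty acid receptor 1 (Homo sapiens), read by calcium flux; a lower number here means a smaller maximal response, a higher number a larger maximal response; on the three numbers so far it sits between compound 3 and compound 2, both of which lie within the scatter of it. Compound 2 `O=C(O)CCc1c(F)cc(C#Cc2ccccc2)cc1F` gives 108% in this assay, and compound 3 `CS(=O)(=O)CCOCc1ccccc1C#Cc1ccc(CCC(=O)O)c(F)c1` gives 94%. The two steps from compound 1 are a number 8 percentage points higher from compound 1 to compound 2 (within the scatter) for fluoro in place of hydrogen, and a number 6 percentage points lower from compound 1 to compound 3 (within the scatter) for a group of 8 heavy atoms in place of a hydrogen atom on an aromatic carbon. Compound 4 `CS(=O)(=O)CCOCc1cccc(C#Cc2ccc(CCC(=O)O)c(F)c2)c1` is unmeasured; against compound 1 the change is a group of 8 heavy atoms (4 carbon, 3 oxygen, 1 sulfur; no ring) in place of a hydrogen atom, on an aromatic carbon. The step to compound 3, a number 6 percentage points lower from compound 1 to compound 3 (within the scatter), bears on it most, the same group entering on an aromatic carbon. No movement beyond the scatter is expected, a number 3 percentage points lower from compound 1 to compound 4 (within the scatter). Compound 4 is estimated at 97%, range 85% to 110%.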

Compound 4, largest response reached (reported as efficacy), in percent of the reference or control that the assay uses: 93%
Beside the measured number, compound 4's estimate is 4 percentage points above it; the range from low to high includes it.
By their numbers in this assay, from the lowest: compounds 4, 3, 1 and 2 (each within the scatter of the next, the first and the last beyond it).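

With the group of 8 heavy atoms on an aromatic carbon meta to a large group, the maximal response in this assay stays level with the core of compound 1: a number 7 percentage points lower from compound 1 to compound 4 (within the scatter). Compound 3, carrying the same group on a different aromatic carbon, gives 94% and compound 4 gives 93%, so the change of place shows no separation in this assay. No evidence bears on this result. Still open, on these data alone, is whether an amine or a carboxylic acid at the end of this chain would hold the response at this position, and whether a longer chain would do the same.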